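Swapping the aryl group on the five-membered ring

This account rests on a few compounds, and the source may have more. Where it says the series, first, only, none or still open, it means among the compounds named here.

Compound 1 `CCOC(=O)C1=Cc2ccccc2OC1(OCc1cn(CC(=O)Nc2cccc(Cl)c2)nn1)C(F)(F)F`: 11600 nM
Compound 2 `CCOC(=O)C1=Cc2ccccc2OC1(OCc1cn(-c2cccc(OC)c2)nn1)C(F)(F)F`: > 150000 nM
Compound 3 `CCOC(=O)C1=Cc2ccccc2OC1(OCc1cc(-c2ccc(OC)cc2)no1)C(F)(F)F`: > 150000 nM

In a functional assay on MCF7 cells (Homo sapiens) for inhibition, read by MTT assay, with a stated time of 24 h (on this read-out lower numbers stand for stronger inhibition and higher numbers for weaker inhibition), compound 1 gives 11600 nM. For compound 2 only a limit is reported, > 150000 nM. Compound 3 likewise stands at a limit, > 150000 nM, which is the limit of > 150000 nM in this assay, at which 2 of the 3 values shown sit. Within the data shown here, the single measured step, an at least 12-fold higher number from compound 1 to compound 2 (1.11 log units; beyond the scatter), concerns a group on an aromatic nitrogen of a different five-membered ring, so it does not bear directly on the change at hand. Compound 4 `CCOC(=O)C1=Cc2ccccc2OC1(OCc1cc(-c2cccc(C(F)(F)F)c2)no1)C(F)(F)F` differs from compound 3 by 3-(trifluoromethyl)phenyl in place of 4-methoxyphenyl on an aromatic carbon. Among the measured compounds shown here, with no comparable step measured, compound 4 is expected to stay at the limit, a step of a number no higher from compound 3 to compound 4 (the limit leaves the size open). The estimate for compound 4 is 150000 nM, between 40000 nM and 150000 nM.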

Compound 4, half-maximal inhibitory concentration: 22100 nM
Compound 4: the middle estimate sits 6.8-fold (0.83 log units) above what was measured; measured number outside the range, below it.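

The aryl group on this carbon, next to the ring nitrogen, clearly matters: in this assay, 3-(trifluoromethyl)phenyl in place of 4-methoxyphenyl gives an at least 6.7-fold lower number from compound 3 to compound 4 (0.83 log units; beyond the scatter). Compound 3 is only a limit, so the true size of this step remains unknown: the limit of > 150000 nM in this assay, at which 2 of the 4 values shown sit.

The swap changes both the group on the phenyl ring and its place there, and these compounds cannot separate the two. As far as these compounds go, how this position would respond to a phenyl ring carrying an amine or a carboxylic acid also remains open.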